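A dimethylsulfamoyl swap from compound 3 to compound 4

A few compounds are considered here, and "the series" means these few. Any claim that something is new, unique, unknown or untested is made for them only; others in the source may bear on it.

- Compound 1 `O=C(Nc1n[nH]c2c1CN(C(=O)c1ccccc1)C2)c1ccc(F)cc1`: 3190 nM
- Compound 2 `CCCCNC(=O)N1Cc2c(NC(=O)c3ccc(C)cc3)nn(C(=O)C3CC3)c2C1`: 17600 nM
- Compound 3 `CC(=O)n1nc(NC(=O)c2ccccc2)c2c1CN(C(=O)c1cccc(F)c1)C2`: 21900 nM

These values come from a functional assay on HCT-116 cells (Homo sapiens) for cytotoxicity, read by sulforhodamine B assay, with a stated time of 48 h; a lower number here means a stronger inhibitor, a higher number a weaker inhibitor. Compound 3 lies within the scatter of compound 2 and beyond the scatter above compound 1.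

Compound 4 `CC(=O)n1nc(NC(=O)c2ccccc2)c2c1CN(S(=O)(=O)N(C)C)C2` carries dimethylsulfamoyl in place of (3-fluorophenyl)carbonyl on an amine nitrogen in a ring. Within the data shown here, no measured pair isolates a single change, so the guide is indirect. Compound 2, which has no aromatic ring on that amine nitrogen, gives 17600 nM, close to compound 3, though it also differs elsewhere. No change beyond the scatter is therefore expected in this assay, and the estimated step is a 1.1-fold lower number from compound 3 to compound 4 (0.04 log units; within the scatter). Compound 4 is expected at 20000 nM, with an estimated range of 7000 nM to 50000 nM.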

Compound 4, half-maximal inhibitory concentration: 35300 nM
For compound 4 the middle estimate is 1.8-fold (0.25 log units) below the measured one; the range from low to high includes it.
By their numbers in this assay, from the lowest: compound 1; then compounds 2, 3 and 4 (each within the scatter of the next).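

Among these compounds, this is the first pair that differs in one place only: in this assay there is a 1.6-fold higher number from compound 3 to compound 4 (0.21 log units; within the scatter) when dimethylsulfamoyl replaces (3-fluorophenyl)carbonyl on the amine nitrogen in a ring. The six-membered aromatic ring of that group can therefore be lost here without a change beyond the scatter. No measurement shown explains this result. As far as these compounds go, whether a methyl group or a simple amine on that nitrogen would read the same stays open. So does whether a carboxylic acid there would move the number beyond the scatter.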